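The source may hold more compounds than are shown below. What is called first, only, known or untested is meant among the compounds shown, and "the series" means these compounds.

Compound 1 `Cc1ccc(S(=O)(=O)c2nc3ccccc3nc2N2CCCC2)cc1`: in a functional assay on KB cells (Homo sapiens) for cytotoxicity, read by MTT assay, with a stated time of 72 h (a lower number here means a stronger inhibitor, a higher number a weaker inhibitor), compound 1 gives > 50000 nM, which is a limit of the assay and not a number.
Compound 2 `COc1ccc(S(=O)(=O)c2nc3ccccc3nc2N2CCCC2)cc1`: in this assay compound 2 gives > 50000 nM, again a limit.
Compound 3 `Cc1ccc(S(=O)(=O)c2nc3ccccc3nc2N2CCC(O)CC2)cc1`: in this assay compound 3 gives 6140 nM.

Compound 3 differs from compound 1 in the core, by 4-hydroxypiperidin-1-yl in place of pyrrolidin-1-yl on an aromatic carbon, and this gives an at least 8.1-fold lower number from compound 1 to compound 3 (0.91 log units; beyond the scatter). The change from compound 1 to compound 2 is methoxy in place of methyl on an aromatic carbon, and its step is a step that the two limits leave unreadable from compound 1 to compound 2, because of the limit of > 50000 nM in this assay, at which 2 of the 3 values shown sit.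

Compound 4 `COc1ccc(S(=O)(=O)c2nc3ccccc3nc2N2CCC(O)CC2)cc1` is not yet measured. It differs from compound 3 by methoxy in place of methyl on an aromatic carbon, the same change as from compound 1 to compound 2, now made on the core of compound 3. The one earlier example of this change gives no readable size, so the expectation rests mostly on compound 3, whose value 6140 nM is the only number shown. The step from compound 3 to compound 4 is expected to be small, a 1.1-fold higher number from compound 3 to compound 4 (0.02 log units; within the scatter). Compound 4 is estimated at 6500 nM, with a likely range from 2500 nM to 18000 nM.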

Compound 4, half-maximal inhibitory concentration: 8060 nM
Beside the measured number, compound 4's estimate is 1.2-fold (0.09 log units) below it; low and high end bracket the measured number.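

In this assay, the change from methyl to methoxy now has one readable size, a 1.3-fold higher number from compound 3 to compound 4 (0.12 log units; within the scatter), so on the core carrying 4-hydroxypiperidin-1-yl the two groups cannot be told apart. Putting 4-hydroxypiperidin-1-yl in place of pyrrolidin-1-yl gives an at least 6.2-fold lower number from compound 2 to compound 4 (0.79 log units; beyond the scatter), so this change points the same way whether the aromatic ring carries methyl or methoxy: the same change on two cores in this assay, an at least 8.1-fold lower number (0.91 log units; beyond the scatter) from compound 1 to compound 3 and an at least 6.2-fold lower number (0.79 log units; beyond the scatter) from compound 2 to compound 4; the limit leaves it open whether they differ. This does not give the true size of that change on either core, and the methoxy change still rests on a single readable example, as the step from compound 1 to compound 2 cannot be read: the limit of > 50000 nM in this assay, at which 2 of the 4 values shown sit.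

The compounds shown leave open whether plain piperidin-1-yl, without the hydroxy group, would also give a readable number, or whether an amine such as piperazin-1-yl would. They also leave open how a chlorine atom or a carboxylic acid would compare with methyl and methoxy on the aromatic ring.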